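Swapping a cyclohexyl for an indole on the benzylic arm

The source may hold more compounds than are shown below. What is called first, only, known or untested is meant among the compounds shown, and "the series" means these compounds.

Of the compounds shown here, three share one core and have been measured in a physicochemical assay for lipophilicity, at pH 7.4; a higher number here means a more lipophilic compound, a lower number a more polar compound. Compound 1 `CNC(=O)c1cc(C(=O)NC2CC2)cn(CC2CCCCC2)c1=O` gives 4. Compound 3 `CNC(=O)c1cc(C(=O)NCCC(C)C)cn(Cc2ccccc2)c1=O` gives 4.8, and compound 2 `CNC(=O)c1ccc(=O)n(Cc2ccccc2)c1` gives 1.6. Among these three numbers compound 1 stands second highest: compound 3 lies above it by a margin beyond the usual scatter, and compound 2 lies well below it, also beyond the scatter.

The unmeasured compound 4 `CNC(=O)c1cc(C(=O)NC2CC2)cn(Cc2cccc3cc[nH]c23)c1=O` differs from compound 1 in a single spot: 1H-indol-7-yl in place of cyclohexyl on a saturated chain carbon bound to an aromatic nitrogen. Among the measured compounds shown here, no directly comparable pair among the measured compounds shows the effect of this exchange, so the size of the step must be judged from the change itself.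

A downward step is expected here, larger than the scatter, because compound 1 sits at 4 and the group that enters brings a hydrogen-bond donor where the leaving cyclohexyl had none. The expected step from compound 1 to compound 4 is a number 1.00 log units lower from compound 1 to compound 4 (beyond the scatter). Compound 4 is therefore estimated at 3, with a likely range from 2.3 to 3.7.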

Compound 4, distribution coefficient: 3.7
Compound 4: middle estimate off by 0.70 log units, on the low side; the range from low to high includes it.
By their numbers in this assay, from the lowest: compound 2; then compounds 4 and 1 (each within the scatter of the next); then compound 3.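

In this assay, putting 1H-indol-7-yl in place of cyclohexyl gives a number 0.30 log units lower from compound 1 to compound 4 (within the scatter), so on this measure the two compounds cannot be told apart. The earlier compounds shown here offered no pair that isolated this position, and this pair now shows that a saturated carbon ring on a saturated chain carbon bound to an aromatic nitrogen can give way to a larger aromatic group carrying 1 hydrogen-bond donor without a step beyond the scatter. No supporting measurement is available to explain why the two numbers stay this close.

This is a single exchange on a single core, so it does not show whether the same result would hold with a different amide on the core. As far as these compounds go, how an amine or a carboxylic acid at this place would read in this assay also remains open.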